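Chloro substitution in the series: compound 2 to compound 4

The source may report more compounds than this note shows. Statements on the series, on what has been measured and on what is new or still open speak of the compounds shown alone.

Three members of the series have been run in an ADME assay on cells (Epithelial cell, Homo sapiens) for antiproliferative activity, read by MTT assay, with a stated time of 48 h; a lower number here means a stronger inhibitor, a higher number a weaker inhibitor. Compound 1 `CCOC(=O)/C(=C/c1ccccc1)CN1C(=O)[C@@H](OC)[C@H]1c1cccc([N+](=O)[O-])c1` came back as "not toxic" (no number reported), with no number attached. For the measured compounds named here, compound 2 `COC(=O)/C(=C/c1ccccc1)CN1C(=O)[C@@H](OC)[C@H]1c1ccccc1` likewise came back as "not toxic" (no number reported) in this assay, so it cannot be placed on a numerical scale; it shares this outcome with one further entry, and only one compound of the set carries a figure at all. That one is compound 3 `CCOC(=O)/C(=C/c1ccccc1)CN1C(=O)[C@@H](OC)[C@H]1c1ccccc1Br`, which in this assay gives 66600 nM, a weak result. Going by the values given here, no step between two measured compounds that differ in a single place is available, so the size of any single change in this assay is unknown for the series.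

Compound 4 `COC(=O)/C(=C/c1ccccc1)CN1C(=O)[C@@H](OC)[C@H]1c1cccc(Cl)c1` is to be measured next. It differs from compound 2 in one place: chloro in place of hydrogen on an aromatic carbon. Among the compounds with values here, with compound 2 carrying no number and no single-change step known, no step beyond the scatter can be expected in either direction, and an outcome without a number is as likely as a figure. Compound 4 is estimated in this assay at 80000 nM, within a range of 30000 nM to 200000 nM, on the weak side like compound 3.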

Compound 4, half-maximal inhibitory concentration: "not toxic" (no number reported)
The entry for compound 4 holds no number; there is nothing to compare the estimate with.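

In this assay compound 4 gives no number, and neither does compound 2, so no step can be read between them. Nothing measured here bears on this outcome. The compounds shown leave open the size of any single change in this assay, including chloro in place of hydrogen on the aromatic ring.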